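A few compounds are considered here, and "the series" means these few. Any claim that something is new, unique, unknown or untested is made for them only; others in the source may bear on it.

Compound 1 `CSc1ccc(NC(=O)Nc2cc(C)nc3ccccc23)cc1`: 16000 nM
Compound 2 `Cc1cc(NC(=O)Nc2ccccc2N)c2ccccc2n1`: > 25000 nM (a limit)
Compound 3 `Cc1ccc(NC(=O)Nc2cc(C)nc3ccccc23)cc1`: > 25000 nM (a limit)

In an ADME assay on HepG2 cells (Homo sapiens) for cytotoxicity, with a stated time of 72 h (a lower number here means that less compound is needed, a higher number that more compound is needed for the effect), compound 3 gives > 25000 nM, which is a limit of the assay and not a number. Compound 3 stands at the limit of > 25000 nM in this assay, at which 2 of the 3 values shown sit.

Compound 4 `Cc1cc(NC(=O)Nc2cccc(F)c2)c2ccccc2n1` has not yet been measured. It carries 3-fluorophenyl in place of 4-methylphenyl on an amide-type nitrogen.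

Within the data shown here, two measured steps bear on this change. Putting methyl in place of methylsulfanyl on an aromatic carbon gives an at least 1.5-fold higher number from compound 1 to compound 3 (0.19 log units; that floor lies within the scatter). Putting 4-methylphenyl in place of 2-aminophenyl on an amide-type nitrogen gives a step that the two limits leave unreadable from compound 2 to compound 3. Among the measured compounds shown here, neither step has a readable size beyond the scatter, and no measured compound carries 3-fluorophenyl, so the new group has no direct reading yet. For the measured compounds named here, compound 1 at 16000 nM is the only compound with a true number, so a true number also remains possible for compound 4.

In this assay no step beyond the scatter is expected, and the estimated step runs a number no higher from compound 3 to compound 4 (the limit leaves the size open). For compound 4 the expected value is 25000 nM, with an estimated range from 13000 nM to 50000 nM.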

Compound 4, half-maximal effective concentration: > 25000 nM
Compound 4: no number, only a limit; the forecaster's own chance of this, stated with the estimate: 65%; the middle value lies on the limit itself.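

In this assay compound 4 gives > 25000 nM, which is a limit of the assay and not a number. Among these compounds, compound 2, compound 3 and compound 4 carry only limits, and no step among them can be read. Still open, from the compounds shown here alone, is whether 2-aminophenyl, 4-methylphenyl and 3-fluorophenyl on the amide-type nitrogen differ at all in this read-out.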